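Swapping the aryl group on the hydrazone carbon

This account rests on a few compounds, and the source may have more. Where it says the series, first, only, none or still open, it means among the compounds named here.

Compound 3 `CN(C)CCn1cnnc1-c1cc(Oc2ccc(NC(=O)N/N=C/c3cccc(Cl)c3Cl)cc2F)ccn1` gives the lowest number of the three measured compounds in a functional assay on HT-29 cells (Homo sapiens) for cytotoxicity, read by MTT assay, with a stated time of 72 h (a higher number here means a weaker inhibitor, a lower number a stronger inhibitor), at 130 nM. Compound 2 `CN(C)CCn1cnnc1-c1cc(Oc2ccc(NC(=O)N/N=C/c3ccc(O)c(Br)c3)cc2F)ccn1` gives 450 nM in this assay, and compound 1 `COc1ccc(OC)c(/C=N/NC(=O)Nc2ccc(Oc3ccnc(-c4nncn4CCN(C)C)c3)c(F)c2)c1` gives 2070 nM. The steps of a 3.5-fold lower number from compound 2 to compound 3 (0.54 log units; beyond the scatter) and a 16-fold lower number from compound 1 to compound 3 (1.20 log units; beyond the scatter) show that this aryl group matters. Compound 4 `Cc1cc(/C=N/NC(=O)Nc2ccc(Oc3ccnc(-c4nncn4CCN(C)C)c3)c(F)c2)cc(C)c1O` differs from compound 3 in one place: 4-hydroxy-3,5-dimethylphenyl in place of 2,3-dichlorophenyl on a carbon with a double bond to nitrogen. The entering group shares a hydroxyl with the group of compound 2, whose step a 3.5-fold lower number from compound 2 to compound 3 (0.54 log units; beyond the scatter) is the closest guide, so a modest weakening is expected, roughly a 3.8-fold higher number from compound 3 to compound 4 (0.59 log units; beyond the scatter). Compound 4 is therefore estimated at 500 nM in this assay, with a range from 150 nM to 1700 nM.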

Compound 4, half-maximal inhibitory concentration: 1220 nM
The estimate for compound 4 lay 2.4-fold (0.39 log units) below the measured number; low and high end bracket the measured number.
By their numbers in this assay, from the lowest: compound 3; then compound 2; then compounds 4 and 1 (each within the scatter of the next).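

In this assay the 4-hydroxy-3,5-dimethylphenyl group gives a 9.4-fold higher number from compound 3 to compound 4 (0.97 log units; beyond the scatter) and also a 2.7-fold higher number from compound 2 to compound 4 (0.43 log units; beyond the scatter) even though compound 2 carries a hydroxyl on this ring too. A shared hydroxyl therefore does not set the number at this carbon. Against the 2,5-dimethoxyphenyl group, the change gives a 1.7-fold lower number from compound 1 to compound 4 (0.23 log units; within the scatter) so these two groups cannot be told apart here.

Going by these compounds, whether an aryl group carrying an amine or a carboxylic acid would come closer to compound 3 stays open. No measurement shown explains these steps.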